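Removing the trifluoromethyl group from compound 3

This account rests on a few compounds, and the source may have more. Where it says the series, first, only, none or still open, it means among the compounds named here.

Measured so far in a functional assay on A549 cells (Homo sapiens) for inhibition, read by CCK-8 assay, with a stated time of 72 h, tested at 10 uM; a higher number here means more inhibition of growth at the concentration tested, a lower number less inhibition of growth
- compound 1 `CN(C)C(=O)c1cc2cnc(Nc3ccc(NC(=O)C4(C(=O)Nc5ccc(Cl)cc5)CC4)cc3)nc2n1C1CCCC1` gives 101%
- compound 2 `COc1cccc(NC(=O)C2(C(=O)Nc3ccc(Nc4ncc5cc(C(=O)N(C)C)n(C6CCCC6)c5n4)cc3)CC2)c1` gives 96%
- compound 3 `CN(C)C(=O)c1cc2cnc(Nc3ccc(NC(=O)C4(C(=O)Nc5ccc(C(F)(F)F)cc5)CC4)cc3)nc2n1C1CCCC1` gives 87.9%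

The position of compound 3 is set by two steps: a number 13.1 percentage points lower from compound 1 to compound 3 (beyond the scatter) and a number 8.1 percentage points lower from compound 2 to compound 3 (within the scatter). Compound 4 `CN(C)C(=O)c1cc2cnc(Nc3ccc(NC(=O)C4(C(=O)Nc5ccccc5)CC4)cc3)nc2n1C1CCCC1` has hydrogen in place of trifluoromethyl on an aromatic carbon. Among the compounds with values here, no measured compound has hydrogen at that place, so the evidence is indirect. Within the data shown here, changing this aryl group gave a number 5 percentage points lower from compound 1 to compound 2 (within the scatter) and the modest a number 13.1 percentage points lower from compound 1 to compound 3 (beyond the scatter), the only step beyond the scatter. A small change is therefore expected, and no step beyond the scatter. The estimated step is a number 4.1 percentage points higher from compound 3 to compound 4 (within the scatter). For compound 4 the expected value is 92%, with an estimated range from 78% to 104%.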

Compound 4, percent growth inhibition at one concentration: 88.8%
Compound 4: middle estimate off by 3.2 percentage points, on the high side, and the stated range covers the measured number.
By their numbers in this assay, from the lowest: compounds 3, 4, 2 and 1 (each within the scatter of the next, the first and the last beyond it).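

In this assay removing the trifluoromethyl group gave a number 0.9 percentage points higher from compound 3 to compound 4 (within the scatter) and so showed directly that hydrogen and trifluoromethyl cannot be told apart at this place. Hydrogen in place of methoxy gave a number 7.2 percentage points lower from compound 2 to compound 4 (within the scatter) while hydrogen in place of chloro gave a number 12.2 percentage points lower from compound 1 to compound 4 (beyond the scatter) and this leaves chloro as the only group shown to stand apart from hydrogen here.

Going by these compounds, whether an amine or a carboxylic acid on this ring would read like chloro or like hydrogen remains open. Nothing available bears on the reason for these steps.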